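The source may report more compounds than this note shows. Statements on the series, on what has been measured and on what is new or still open speak of the compounds shown alone.

Of the compounds shown here, two have been measured so far in an assay on mitochondria from liver for inhibition of kynurenine 3-monooxygenase (Mus musculus), read by LC-MS, with stated times of 5 min and 30 min; on this read-out higher numbers stand for weaker inhibition and lower numbers for stronger inhibition. Compound 1 `Cc1cccc(S(=O)(=O)Nc2ccc(-c3cccc(Cl)c3)nn2)c1` gives 101 nM in this assay, the lower of the two numbers. Compound 2 `CN(C)c1ccc(S(=O)(=O)Nc2ccc(-c3cccc(Cl)c3)nn2)cc1`, which carries a dimethylamino group on the ring attached to the sulfonamide, gives 402 nM in this assay, a number beyond the scatter above that of compound 1. Compound 3 `CN(C)c1cccc(S(=O)(=O)Nc2ccc(-c3cccc(Cl)c3)nn2)c1` is the next to be tested; it differs from compound 1 by dimethylamino in place of methyl on an aromatic carbon. The entering group is thus the same dimethylamino that compound 2 carries, here set in place of the methyl of compound 1. Because compound 2 with its 402 nM stands clearly weaker than compound 1, a shift in the same direction, though perhaps smaller, is expected. The expected step is a 2.5-fold higher number from compound 1 to compound 3 (0.39 log units; beyond the scatter). Compound 3 is therefore estimated to give about 250 nM in this assay, most likely between 80 nM and 800 nM.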

Compound 3, half-maximal inhibitory concentration: 31.7 nM
Beside the measured number, compound 3's estimate is 7.9-fold (0.90 log units) above it; the whole stated range lies above it.
By their numbers in this assay, from the lowest: compound 3; then compound 1; then compound 2.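

Set in place of methyl on an aromatic carbon meta to a large group, dimethylamino brings a 3.2-fold lower number from compound 1 to compound 3 (0.50 log units; beyond the scatter) in this assay and so shows that this position accepts a larger group containing nitrogen, with stronger inhibition as the outcome. The group alone does not fix the result, since compound 3 gives 31.7 nM while compound 2 gives 402 nM with the same dimethylamino placed elsewhere on that ring. No supporting measurement is available to explain the step. Still open, as far as these compounds go, is whether the nitrogen itself matters here, which a methoxy group or an ethyl chain at this position could help to test. A diethylamino group or a smaller methylamino group would show how far the change in the amine can go.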